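Replacing a chain hydroxamic acid with a carbamate link

The source may hold more compounds than are shown below. What is called first, only, known or untested is meant among the compounds shown, and "the series" means these compounds.

Measured compounds:
- compound 1, `O=S(=O)(c1ccccc1)c1c(OCCCCCCO)no[n+]1[O-]`: "not determined" (no result reported)
- compound 2, `O=C(CCCCCCOc1no[n+]([O-])c1S(=O)(=O)c1ccccc1)NO`: 1210 nM

Two compounds share one core with a phenylsulfonyl group and a long oxygen-linked chain. Compound 1 was run without any reported outcome. Within the data shown here, in a functional assay on MDA cells (Homo sapiens) for inhibition, read by MTT assay, with a stated time of 48 h (on this read-out lower numbers stand for stronger inhibition and higher numbers for weaker inhibition), compound 2 gives 1210 nM, the only number available, so compound 2 stands alone and nothing can be said about its rank.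

Compound 3, `O=C(NO)OCCOCCOc1no[n+]([O-])c1S(=O)(=O)c1ccccc1`, differs from compound 2 by 2-((hydroxycarbamoyl)oxy)ethoxy in place of 4-(hydroxycarbamoyl)butyl on a saturated chain carbon, two bonds along the chain from an oxygen on an aromatic ring.

Among the measured compounds shown here, with no measured pair to lean on, the expectation for this change rests on the single value of compound 2 alone. The estimate for compound 3 is a modest weakening in this assay, a step from compound 2 to compound 3 of a 2.3-fold higher number from compound 2 to compound 3 (0.36 log units; beyond the scatter), just beyond the usual scatter. Compound 3 is therefore expected to give about 2800 nM, within a range from 900 nM to 9000 nM.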

Compound 3, half-maximal inhibitory concentration: 15800 nM
Beside the measured number, compound 3's estimate is 5.6-fold (0.75 log units) below it; the measured number lies above the stated range.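

In this assay, this position proves sensitive to what the chain is made of, not only to how long it is: the swap gives a 13-fold higher number from compound 2 to compound 3 (1.12 log units; beyond the scatter), a large loss of inhibition. The leaving 4-(hydroxycarbamoyl)butyl and the entering 2-((hydroxycarbamoyl)oxy)ethoxy both hold 8 heavy atoms and 2 hydrogen-bond donors, but the entering group has 3 carbon and 4 oxygen atoms where the leaving group has 5 carbon and 2 oxygen atoms. Several atoms change in this single step, so it cannot show which of them matters, and no separate data explain the loss.

Compound 1 reads "not determined" (no result reported), so it adds no comparison. On these data alone, whether a carboxylic acid or an amine in place of 4-(hydroxycarbamoyl)butyl would give a number nearer that of compound 2 or compound 3 remains open.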